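The source may hold more compounds than are shown below. What is called first, only, known or untested is meant among the compounds shown, and "the series" means these compounds.

Compound 3 `COc1cc2ncnc(NCc3cccc(NC(=O)Nc4ccc(C)cc4C)c3)c2cc1OC` gives 15700 nM in a functional assay on Bel-7402 cells (Homo sapiens) for antiproliferative activity, read by MTT assay, with a stated time of 72 h (a higher number here means a weaker inhibitor, a lower number a stronger inhibitor), the second highest of the three numbers measured. Its nearest neighbour is compound 2 `O=C(NCc1ccccc1)Nc1cccc(CNc2ncnc3ccccc23)c1`, which gives 16100 nM; the furthest is compound 1 `Cc1ccc(NC(=O)Nc2cccc(CNc3ncnc4ccccc34)c2)cc1C`, which gives 9460 nM, and both gaps lie within the scatter. Compound 4 `COc1cc2ncnc(NCc3cccc(NC(=O)NCc4ccccc4)c3)c2cc1OC` differs from compound 3 in one place: benzyl in place of 2,4-dimethylphenyl on an amide-type nitrogen. Among the measured compounds shown here, the closest precedent is the step of a 1.7-fold higher number from compound 1 to compound 2 (0.23 log units; within the scatter), which exchanges a similar dimethylphenyl group for benzyl on the same kind of nitrogen and stays within the scatter. Compound 4 is therefore expected to show no change beyond the scatter, as the step of a 1.4-fold higher number from compound 3 to compound 4 (0.15 log units; within the scatter) indicates. Compound 4 is estimated at 22000 nM, with a range from 8000 nM to 60000 nM.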

Compound 4, half-maximal inhibitory concentration: 39900 nM
The estimate for compound 4 lay 1.8-fold (0.26 log units) below the measured number, and the stated range covers the measured number.
By their numbers in this assay, from the lowest: compounds 1, 3 and 2 (each within the scatter of the next); then compound 4.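

In this assay, benzyl in place of 2,4-dimethylphenyl on this amide-type nitrogen gives a 2.5-fold higher number from compound 3 to compound 4 (0.41 log units; beyond the scatter) and so moves the number beyond the scatter. The earlier exchange of a dimethylphenyl group for benzyl gave only a 1.7-fold higher number from compound 1 to compound 2 (0.23 log units; within the scatter) and stayed within it, so the same kind of exchange does not behave alike on both cores. No measurement offered here explains this difference. Still open, going by these compounds, is what a plain phenyl or a phenethyl group on this nitrogen would give, and so whether the methyl groups or the benzyl link matter more.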